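A few compounds are considered here, and "the series" means these few. Any claim that something is new, unique, unknown or untested is made for them only; others in the source may bear on it.

Three compounds have been measured in a functional assay on MIA PaCa-2 cells (Homo sapiens) for inhibition, read by MTT assay, with a stated time of 72 h; on this read-out higher numbers stand for weaker inhibition of growth and lower numbers for stronger inhibition of growth:

Compound 1, `O=[N+]([O-])c1ccc(S(=O)(=O)NCCCCCCNCc2ccc(Br)cc2)cc1`, gives 9800 nM.
Compound 2, `O=S(=O)(NCCCNCc1cccc2ccccc12)c1cc(C(F)(F)F)cc(C(F)(F)F)c1`, gives 2800 nM.
Compound 3, `O=S(=O)(NCCCCCCNCc1ccc(Br)cc1)c1cc(C(F)(F)F)cc(C(F)(F)F)c1`, gives 2970 nM.

Among these three numbers compound 1 stands highest, which on this read-out means it is the weakest inhibitor of growth of the set. The nearest number is that of compound 3, which is lower by a margin beyond the usual scatter of repeated measurements, and the number of compound 2 is lower still, also beyond that scatter. For the measured compounds named here, no pair of measured compounds differs in only one place, so none of these gaps can be tied to a single structural change; the values can only be set side by side.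

Compound 4, `CC(C)c1ccc(S(=O)(=O)NCCCCCCNCc2ccc(Br)cc2)cc1`, has not yet been measured. It differs from compound 1 in one place: isopropyl in place of nitro on an aromatic carbon. Nothing measured shows how this particular exchange plays out in this assay, so the expectation rests on the fact that all three measured numbers lie fairly close together. The expected step is a 1.8-fold lower number from compound 1 to compound 4 (0.25 log units; within the scatter), toward lower numbers, and it may well not exceed the scatter. Compound 4 is estimated at 5500 nM, with a range from 1800 nM to 17000 nM.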

Compound 4, concentration for 50% growth inhibition: 5730 nM
Beside the measured number, compound 4's estimate is 1.0-fold (0.02 log units) below it, within the range that was stated.
By their numbers in this assay, from the lowest: compounds 2, 3, 4 and 1 (each within the scatter of the next, the first and the last beyond it).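

For the compounds shown here, this is the first pair in the set that differs in only one place, so a single exchange can now be read on its own: in this assay, putting isopropyl in place of nitro on the aromatic carbon para to a large group gives a 1.7-fold lower number from compound 1 to compound 4 (0.23 log units; within the scatter). Nitro and isopropyl each hold three heavy atoms, but nitro carries two hydrogen-bond acceptors and isopropyl, made of carbon only, carries none, and this difference leaves the two compounds indistinguishable on this read-out. Nothing available explains this result, so the pair records only what happened and not why.

This single pair cannot show whether the position tolerates most groups or whether these two simply happen to give similar numbers, and a carboxylic acid, an amine or a longer alkyl chain on the same carbon could give a different answer. Going by these compounds alone, it also remains open whether the same exchange would behave in the same way on a core other than the one shared by compound 1 and compound 4.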